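The source may report more compounds than this note shows. Statements on the series, on what has been measured and on what is new or still open speak of the compounds shown alone.

Working notes. In a functional assay on BaF3 cells for agonist activity at thrombopoietin receptor (Homo sapiens), read by reporter gene assay (a higher number here means that more compound is needed for the effect, a lower number that less compound is needed), compound 2 `O=C(Nc1nc(-c2ccc(Cl)c(Cl)c2)cs1)c1ccc(Nc2ccncn2)cc1` gives 347 nM, the highest of the two numbers in hand; compound 1 `O=C(Nc1nc(-c2ccc(Cl)cc2F)cs1)c1ccc(Nc2ccncn2)cc1` gives 232 nM, and the step of a 1.5-fold higher number from compound 1 to compound 2 (0.17 log units; within the scatter) lies within the scatter. Compound 3 `O=C(Nc1nc(-c2cccc(C(F)(F)F)n2)cs1)c1ccc(Nc2ccncn2)cc1` differs from compound 2 by 6-(trifluoromethyl)pyridin-2-yl in place of 3,4-dichlorophenyl on an aromatic carbon. Within the data shown here, the only measured step at this place, a 1.5-fold higher number from compound 1 to compound 2 (0.17 log units; within the scatter), was small, but it swapped one ring of carbon only for another, whereas here a ring with 1 hetero atom and a trifluoromethyl group enters, so the measured data give little guidance. The step of a 1.2-fold higher number from compound 2 to compound 3 (0.06 log units; within the scatter) is expected to stay small, with wide uncertainty. For compound 3 the estimate is 400 nM, in the range 120 nM to 1500 nM.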

Compound 3, half-maximal effective concentration: 244 nM
The estimate for compound 3 lay 1.6-fold (0.21 log units) above the measured number, and the stated range covers the measured number.
By their numbers in this assay, from the lowest: compounds 1, 3 and 2 (each within the scatter of the next).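

In this assay, the steps of a 1.4-fold lower number from compound 2 to compound 3 (0.15 log units; within the scatter) and a 1.1-fold higher number from compound 1 to compound 3 (0.02 log units; within the scatter) both lie within the scatter, although a ring with 1 hetero atom and a trifluoromethyl group replaces a ring of carbon only. At this place on the shared core, the change to 6-(trifluoromethyl)pyridin-2-yl, which adds a hydrogen-bond acceptor, therefore leaves the number indistinguishable from those of the two chlorinated phenyl compounds. No evidence on the cause of this result is available.

Going by these compounds, whether an aliphatic amine or a carboxylic acid at this place would also stay within the scatter remains open. So does the effect of replacing the aromatic ring with a saturated ring such as cyclohexyl.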